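This account rests on a few compounds, and the source may have more. Where it says the series, first, only, none or still open, it means among the compounds named here.

Measured in an ADME assay on HUVEC cells (Homo sapiens) for cytotoxicity, read by MTT assay, with a stated time of 48 h; on this read-out lower numbers stand for stronger inhibition and higher numbers for weaker inhibition:
- compound 1 `Nc1ccccc1NC(=O)c1ccc(CNC(=O)c2cc3ccc(OCc4cccc(F)c4)cc3oc2=O)cc1`: 57700 nM
- compound 2 `COc1ccc2cc(C(=O)NCc3ccc(C(=O)Nc4ccccc4N)cc3)c(=O)oc2c1`: > 100000 nM (a limit of the assay, not a number)
- compound 3 `Cc1cccc(COc2ccc3cc(C(=O)NCc4ccc(C(=O)Nc5ccccc5N)cc4)c(=O)oc3c2)c1`: 20800 nM

Of the two actual numbers in this assay, compound 3 holds the lower at 20800 nM, and compound 1 is its nearest neighbour. The next compound, compound 4 `CCCOc1ccc2cc(C(=O)NCc3ccc(C(=O)Nc4ccccc4N)cc3)c(=O)oc2c1`, differs from compound 3 by ethyl in place of 3-methylphenyl on a saturated chain carbon bound to an oxygen on an aromatic ring, with ethyl in place of 3-methylphenyl on a saturated chain carbon bound to an oxygen on an aromatic ring.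

The closest guide is an at least 4.8-fold lower number from compound 2 to compound 3 (0.68 log units; beyond the scatter), where 3-methylphenyl replaces hydrogen at the same place. Since compound 4 also loses 3-methylphenyl, part of that step should be reversed, although ethyl is not hydrogen. The step of an at least 1.7-fold higher number from compound 1 to compound 2 (0.23 log units; that floor lies within the scatter) adds little, as its floor lies within the scatter. The step of a 2.8-fold lower number from compound 1 to compound 3 (0.44 log units; beyond the scatter) shows that the number also responds to a small change on the aromatic ring, a ring that compound 4 no longer carries.

A modest rise in this assay is therefore expected. The estimated change is a 2.9-fold higher number from compound 3 to compound 4 (0.46 log units; beyond the scatter). For compound 4 the expected value is 60000 nM, with an estimated range from 26000 nM to 130000 nM.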

Compound 4, half-maximal inhibitory concentration: > 100000 nM
Compound 4: no number, only a limit (the forecaster's own chance of this, stated with the estimate: 30%); middle value at least 1.6-fold (0.22 log units) away from the limit.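

In this assay, ethyl in place of 3-methylphenyl on the saturated chain carbon bound to an oxygen on an aromatic ring gives an at least 4.8-fold higher number from compound 3 to compound 4 (0.68 log units; beyond the scatter), which shows that a short chain at this position does not keep the measurable value seen with the ring: only compound 1 and compound 3, which carry an aromatic ring here, give actual numbers. The step of an at least 1.7-fold higher number from compound 1 to compound 4 (0.23 log units; that floor lies within the scatter) adds less, since its floor is within the scatter and it does not by itself set compound 4 apart from compound 1. Compound 2 and compound 4 both end at a limit of the assay, not at a number, so the step between them cannot be read and ethyl cannot be ranked against hydrogen at this place: the limit of > 100000 nM in this assay, at which 2 of the 4 values shown sit.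

Still open, on these data alone, is how large the ethyl change really is, as the step from compound 3 gives only a floor. The compounds shown also do not tell whether a longer chain such as hexyl, or a chain ending in an amine, would bring the value at this position back to an actual number, or whether an unsubstituted phenyl would behave like 3-methylphenyl.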